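Working notes: from cycloheptyl to 4-ethylcyclohexyl

The compounds below may be only part of what the source reports. "The series", "measured", "known", "first", "only" and "open" are said of these compounds alone.

- compound 1 `CCC(C)C(=O)N1CCC(NC(=O)NC2CCCCC2)CC1`: 923 ug/mL
- compound 2 `CCC(C)C(=O)N1CCC(NC(=O)NC2CCCCCC2)CC1`: 278 ug/mL
- compound 3 `CCC(C)C(=O)N1CCC(NC(=O)N[C@H]2CC[C@H](CC)CC2)CC1`: not yet measured

Among the measured compounds shown here, in a physicochemical assay for solubility, in phosphate buffer, at pH 7.4 (on this read-out higher numbers stand for higher solubility and lower numbers for lower solubility), compound 2 holds the lower of the two numbers so far, at 278 ug/mL, and compound 1 is the only neighbour. The next structural change is 4-ethylcyclohexyl in place of cycloheptyl on an amide-type nitrogen, which puts 4-ethylcyclohexyl in place of cycloheptyl on an amide-type nitrogen, with the rest of the molecule unchanged.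

For the measured compounds named here, only one measured step bears on this change: a 3.3-fold lower number from compound 1 to compound 2 (0.52 log units; beyond the scatter). It is modest but beyond the scatter, and it also alters the ring group at that same place. A single step sets no trend, and it does not cover an ethyl-bearing ring. Going by the values given here, it still offers the only guide to size and direction, so a step of similar modest size towards a lower number is expected in this assay. The estimated step is a 2.5-fold lower number from compound 2 to compound 3 (0.40 log units; beyond the scatter). For compound 3 the expected value is 110 ug/mL, with an estimated range of 35 ug/mL to 300 ug/mL.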

Compound 3, solubility: 39.5 ug/mL
Estimate against measurement, compound 3: 2.8-fold (0.44 log units) above, within the range that was stated.
By their numbers in this assay, from the lowest: compound 3; then compound 2; then compound 1.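

In this assay, the three ring groups on the amide-type nitrogen now give three numbers that all lie beyond the scatter of one another, with a 7.0-fold lower number from compound 2 to compound 3 (0.85 log units; beyond the scatter) extending the fall seen with cycloheptyl. The larger comparison is with the parent ring: ethyl in place of hydrogen on a saturated ring carbon accounts for the whole difference in a 23-fold lower number from compound 1 to compound 3 (1.37 log units; beyond the scatter), the largest step among the compounds shown, so a return to the six-membered ring of compound 1 does not by itself bring back the higher number when that ring carries ethyl. Nothing measured here gives a reason for either step.

The compounds shown leave open how methyl, hydroxyl or an amine in place of ethyl on the ring would read in this assay, and so whether the step follows ethyl specifically or any group at that ring carbon. Also open, on these data alone, is whether the other stereoisomer of 4-ethylcyclohexyl, with its 2 defined stereocentres arranged differently, would give a number close to that of compound 3 or one beyond the scatter of it.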